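Acetyl for methylsulfonyl on the ortho substituent

This account rests on a few compounds, and the source may have more. Where it says the series, first, only, none or still open, it means among the compounds named here.

Compound 1 `CC(Oc1ccccc1Br)C1=NCCN1` gives 282 nM in an assay on CHO cells for displacement of a labelled ligand from Alpha-2C adrenergic receptor (Homo sapiens); a lower number here means a stronger inhibitor, a higher number a weaker inhibitor.
Compound 2 `CCc1ccccc1OC(C)C1=NCCN1` gives 288 nM in this assay.
Compound 3 `CC(Oc1ccccc1S(C)(=O)=O)C1=NCCN1` gives 3800 nM in this assay.

Of the three measured compounds, compound 3 carries the highest number in this assay and so is the weakest binder of the set; its steps to the other two are both beyond the scatter. The step from compound 3 to the unmeasured compound 4 `CC(=O)c1ccccc1OC(C)C1=NCCN1` is acetyl in place of methylsulfonyl on an aromatic carbon. Going by the values given here, the steps that bear on it are a 13-fold higher number from compound 1 to compound 3 (1.13 log units; beyond the scatter) and a 13-fold higher number from compound 2 to compound 3 (1.12 log units; beyond the scatter), which show the methylsulfonyl group going with a large rise in the number, whereas a 1.0-fold higher number from compound 1 to compound 2 (0.01 log units; within the scatter) shows bromo and ethyl within the scatter of each other. Acetyl retains one hydrogen-bond acceptor where methylsulfonyl had two, so a partial return toward the values of compound 1 and compound 2 is expected rather than a full one. The expected step is a 3.2-fold lower number from compound 3 to compound 4 (0.50 log units; beyond the scatter). Compound 4 is therefore estimated at 1200 nM in this assay, with a range from 400 nM to 4000 nM.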

Compound 4, inhibition constant: 7410 nM
Compound 4: the middle estimate sits 6.2-fold (0.79 log units) below what was measured; measured number outside the range, above it.
By their numbers in this assay, from the lowest: compounds 1 and 2 (each within the scatter of the next); then compounds 3 and 4 (each within the scatter of the next).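

In this assay, acetyl in place of methylsulfonyl on this aromatic carbon gives a 2.0-fold higher number from compound 3 to compound 4 (0.29 log units; within the scatter) and so does not separate the two groups, although acetyl has 1 hydrogen-bond acceptor and methylsulfonyl 2. Acetyl instead parts from the other two groups, with a 26-fold higher number from compound 2 to compound 4 (1.41 log units; beyond the scatter) and with a 26-fold higher number from compound 1 to compound 4 (1.42 log units; beyond the scatter) as well. The large rise in the number therefore does not belong to methylsulfonyl alone: the four compounds fall into two sets, bromo and ethyl on one side and methylsulfonyl and acetyl on the other, and none goes against this split. Nothing measured here accounts for the split.

On these data alone, it remains open on which side a methoxy group, an amine or a carboxylic acid on this aromatic carbon would fall. As far as these compounds go, it is also open whether the split would hold for a longer chain, such as propyl or propanoyl.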